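A few compounds are considered here, and "the series" means these few. Any claim that something is new, unique, unknown or untested is made for them only; others in the source may bear on it.

Measured so far:
- Compound 1 `Cc1ccccc1-c1nc(CN2CCC(C(=O)NCCCN3CCC(C)(C)CC3)CC2)c(C)o1`: > 69 ug/mL, a limit
- Compound 2 `Cc1oc(-c2ccc(Cl)cc2)nc1CN1CCC(C(=O)NCCCN2C[C@H](C)C[C@H](C)C2)CC1`: > 72 ug/mL, a limit

In a physicochemical assay for solubility, in phosphate buffer, measured as kinetic solubility, at pH 7.4 (a lower number here means a less soluble compound, a higher number a more soluble compound), compound 1 gives > 69 ug/mL, which is a limit and not a number. Compound 2 likewise gives only a limit, > 72 ug/mL. Compound 3 `Cc1oc(-c2c(Cl)cccc2Br)nc1CN1CCC(C(=O)NCCCN2C[C@H](C)C[C@H](C)C2)CC1` carries 2-bromo-6-chlorophenyl in place of 4-chlorophenyl on an aromatic carbon. Going by the values given here, no measured step sizes this change, and no direction can be drawn from two limits. The expected step that the limit leaves unreadable from compound 2 to compound 3 is none beyond the scatter. For compound 3 the estimate in this assay is 78 ug/mL, with an expected range of 35 ug/mL to 95 ug/mL.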

Compound 3, solubility: > 83 ug/mL
Compound 3: a limit, no number; the forecaster's own chance of this, stated with the estimate: 60%; middle value at least 1.0-fold (0.02 log units) away from the limit.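

Going by these compounds alone, compound 2 and compound 3 both stand only as limits, so no step between them can be read. The compounds shown leave open whether 2-bromo-6-chlorophenyl in place of 4-chlorophenyl changes the read-out at all, and in which direction.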